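Swapping chloro for phenyl at a measurement limit

This account rests on a few compounds, and the source may have more. Where it says the series, first, only, none or still open, it means among the compounds named here.

Values from an ADME assay on J774 cells (Mus musculus) for cytotoxicity, read by resazurin assay, with a stated time of 72 h (on this read-out lower numbers stand for higher toxicity in this test and higher numbers for lower toxicity in this test), for three compounds
- compound 1 `C/C(=N\Nc1nc(-c2ccncc2)cs1)c1ccc(Cl)c(Cl)c1` gives 39800 nM
- compound 2 `C/C(=N\Nc1nc(-c2ccc(F)cc2)cs1)c1ccc(Cl)c(Cl)c1` gives > 50000 nM as a limit
- compound 3 `C/C(=N\Nc1nc(-c2ccc(Cl)cc2)cs1)c1ccc(Cl)c(Cl)c1` gives > 50000 nM as a limit

In this assay compound 3 gives > 50000 nM as a limit, not a number. This is the limit of > 50000 nM in this assay, at which 2 of the 3 values shown sit, and leaves its true place open. Compound 4 `C/C(=N\Nc1nc(-c2ccc(-c3ccccc3)cc2)cs1)c1ccc(Cl)c(Cl)c1` differs from compound 3 by a single change phenyl in place of chloro on an aromatic carbon and so carries phenyl in place of chloro on an aromatic carbon.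

Going by the values given here, three measured steps bear on this change. Replacing pyridin-4-yl gave an at least 1.2-fold higher number from compound 1 to compound 2 (0.09 log units; that floor lies within the scatter) and also an at least 1.2-fold higher number from compound 1 to compound 3 (0.09 log units; that floor lies within the scatter) as a second case. Chloro in place of fluoro gave a step that the two limits leave unreadable from compound 2 to compound 3 as the third. None of these steps brings in a group as large as phenyl, so they offer only weak guidance. No step beyond the scatter is expected, and the estimated move is an at least 1.2-fold lower number from compound 3 to compound 4 (0.09 log units; that floor lies within the scatter) towards lower numbers. For compound 4 the expected value is 40000 nM with an estimated range from 15000 nM to 50000 nM in this assay on this reading.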

Compound 4, half-maximal cytotoxic concentration: > 50000 nM
Compound 4: no number, only a limit; the forecaster's own chance of this, stated with the estimate: 55%; at least 1.2-fold (0.09 log units) between middle value and limit.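

Going by these compounds alone, compound 4 also gives a limit rather than a number in this assay, so neither the step from compound 2 to compound 4 nor the one from compound 3 to compound 4 can be read. The true values of compound 2, compound 3 and compound 4, and whether phenyl in place of chloro changes the read-out at all, stay open at a shared limit: the limit of > 50000 nM in this assay, at which 3 of the 4 values shown sit.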